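The source may hold more compounds than are shown below. What is called first, only, known or untested is meant among the compounds shown, and "the series" means these compounds.

Measured in a functional assay on NCI-H1650 cells (Homo sapiens) for inhibition, read by MTT assay, with a stated time of 48 h; a lower number here means a stronger inhibitor of growth, a higher number a weaker inhibitor of growth:
- compound 1 `O=S(=O)(NCCCN1CCCCc2ccccc21)c1ccc(OC(F)(F)F)cc1`: "not active" (no number reported)
- compound 2 `O=S(=O)(NC1CCOC2(C1)c1ccccc1CCc1ccccc12)c1ccc(OC(F)(F)F)cc1`: > 40000 nM

Compound 1 gave no number in this assay. For compound 2, the reading of > 40000 nM is a limit of the assay and not a number.

Compound 3 `O=S(=O)(NC1CCOC2(C1)c1ccccc1CCc1ccccc12)c1ccc(Cl)cc1` keeps the core of compound 2 and changes one group: chloro in place of trifluoromethoxy on an aromatic carbon. The swap lies para to a large group and turns a 4-(trifluoromethoxy)phenyl into a 4-chlorophenyl.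

Within the data shown here, no measured pair here shows what such a swap does, so no change beyond the scatter is expected in this assay, and growth inhibition should stay weak. The estimated change is a number no higher from compound 2 to compound 3 (the limit leaves the size open). Compound 3 is expected at 40000 nM, with an estimated range of 15000 nM to 80000 nM.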

Compound 3, concentration for 50% growth inhibition: > 40000 nM
Compound 3 gave a limit, no number (the forecaster's own chance of this, stated with the estimate: 65%); the middle value lies on the limit itself.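

No step from compound 2 to compound 3 can be read, because each of the two readings is a limit and not a number: the limit of > 40000 nM in this assay, at which 2 of the 3 values shown sit.

The compounds shown leave open whether chloro in place of trifluoromethoxy changes growth inhibition at all, and at what concentration compound 1, compound 2 or compound 3 would inhibit growth.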